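Amide nitrogen substituent and antiproliferative potency in one series

This account rests on a few compounds, and the source may have more. Where it says the series, first, only, none or still open, it means among the compounds named here.

Compound 2 `CCn1c(C(=O)Nc2ccc(OC(F)(F)F)cc2)ccc1C(CC)(CC)c1ccc(OCCC(O)(CC)CC)c(C)c1` gives in a functional assay on MCF7 cells (Homo sapiens) for antiproliferative activity, read by MTT assay, with a stated time of 48 h (a higher number here means a weaker inhibitor, a lower number a stronger inhibitor), only a limit, > 50000 nM; its standing among the three measured compounds is the limit itself (the limit of > 50000 nM in this assay, at which 1 of the 3 values shown sits). Compound 1 `CCn1c(C(=O)NCCN)ccc1C(CC)(CC)c1ccc(OCCC(O)(CC)CC)c(C)c1` gives 670 nM in this assay, and compound 3 `CCn1c(C(=O)NC(C)C(=O)O)ccc1C(CC)(CC)c1ccc(OCCC(O)(CC)CC)c(C)c1` gives 19700 nM. All measured steps run through the amide nitrogen: an at least 74-fold higher number from compound 1 to compound 2 (1.87 log units; beyond the scatter), a 29-fold higher number from compound 1 to compound 3 (1.47 log units; beyond the scatter), and an at least 2.5-fold lower number from compound 2 to compound 3 (0.40 log units; beyond the scatter). Compound 4 `CCC(C)C(CO)NC(=O)c1ccc(C(CC)(CC)c2ccc(OCCC(O)(CC)CC)c(C)c2)n1CC` differs from compound 2 at the same place: 1-(hydroxymethyl)-2-methylbutyl in place of 4-(trifluoromethoxy)phenyl on an amide-type nitrogen. Within the data shown here, a neutral chain here has no measured precedent; both chains seen so far, whether 2-aminoethyl or 1-carboxyethyl, sit at lower numbers than the aryl. Compound 4 is therefore expected to show an at least 10-fold lower number from compound 2 to compound 4 (1.00 log units; beyond the scatter), and is estimated at 5000 nM, within a range from 1000 nM to 30000 nM.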

Compound 4, half-maximal inhibitory concentration: 29100 nM
Compound 4: the middle estimate sits 5.8-fold (0.76 log units) below what was measured, and the stated range covers the measured number.
By their numbers in this assay, from the lowest: compound 1; then compounds 3 and 4 (each within the scatter of the next). At a limit, above all of these: compound 2.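

Against 2-aminoethyl, the 1-(hydroxymethyl)-2-methylbutyl chain gives a 43-fold higher number from compound 1 to compound 4 (1.64 log units; beyond the scatter), and against 1-carboxyethyl it gives a 1.5-fold higher number from compound 3 to compound 4 (0.17 log units; within the scatter), so only compound 1 stands apart among the three compounds with numbers. Against the aryl, the change gives an at least 1.7-fold lower number from compound 2 to compound 4 (0.23 log units; that floor lies within the scatter). Compound 2 remains a limit of the assay, not a number: the limit of > 50000 nM in this assay, at which 1 of the 4 values shown sits.

From the compounds shown here alone, whether the amine itself or the short chain carries the number of compound 1 stays open. A longer aminoalkyl chain, a dimethylamino end or a 2-hydroxyethyl chain on an amide-type nitrogen would separate these.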